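Salicylanilide nitriles: methyl to trifluoromethyl on the phenol ring

The source may hold more compounds than are shown below. What is called first, only, known or untested is meant among the compounds shown, and "the series" means these compounds.

Measured compounds and their values:
- compound 1, `Cc1ccc(C(=O)Nc2ccc(C#N)cc2)c(O)c1`: 2560 nM
- compound 2, `Cc1ccc(O)c(C(=O)Nc2ccc(C#N)cc2)c1`: 3370 nM
- compound 3, `N#Cc1ccc(NC(=O)c2cccc(Br)c2O)cc1`: 3260 nM

All three were run in a functional assay on KG-1 cells (Homo sapiens) for cytotoxicity, read by luminescence and CellTiter-Glo, with a stated time of 3 days; a lower number here means a stronger inhibitor, a higher number a weaker inhibitor. Compound 1 gives 2560 nM, compound 2 gives 3370 nM and compound 3 gives 3260 nM. The three numbers lie close together: the gap from compound 2 to compound 3 and the gap from compound 2 to compound 1 both fall within the usual scatter of repeated measurements, so no ranking among them is claimed. No pair of these compounds differs in a single place, so no measured step is available to calibrate the next change.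

Compound 4, `N#Cc1ccc(NC(=O)c2cc(C(F)(F)F)ccc2O)cc1`, has not yet been measured. It differs from compound 2 in one place: trifluoromethyl in place of methyl on an aromatic carbon, on an aromatic carbon of a six-membered aromatic ring of carbon only, meta to a large group and para to a hydroxy group. Nothing in the measured set tells how this exchange moves the readout, and the three measured compounds themselves stay within scatter of one another, so the step from compound 2 to compound 4 is expected to be small in either direction, most likely none beyond the scatter, with a 1.3-fold lower number from compound 2 to compound 4 (0.11 log units; within the scatter) as the working expectation. For compound 4 the estimate is 2600 nM, within a range of 900 nM to 7500 nM.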

Compound 4, half-maximal inhibitory concentration: 4810 nM
Estimate against measurement, compound 4: 1.9-fold (0.27 log units) below; the range from low to high includes it.
By their numbers in this assay, from the lowest: compounds 1, 3, 2 and 4 (each within the scatter of the next).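

In this assay, among the compounds shown here, trifluoromethyl in place of methyl on the aromatic carbon para to a hydroxy group gives a 1.4-fold higher number from compound 2 to compound 4 (0.15 log units; within the scatter), the only step so far that isolates a single change. At this position, the read-out does not separate the two groups, although the entering group has 4 heavy atoms and the leaving group has 1. No measurement shown bears on why this exchange reads as it does.

The compounds shown leave open how an amine, a carboxylic acid or a longer chain on this same carbon would read in this assay. They also leave open whether the exchange of methyl for trifluoromethyl would read the same at the carbon that carries the methyl in compound 1.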